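Fluoro in place of bromo: what to expect

The source may hold more compounds than are shown below. What is called first, only, known or untested is meant among the compounds shown, and "the series" means these compounds.

Of the compounds shown here, two built on the same core have so far been tested in an ADME assay on MT4 cells (Homo sapiens) for cytotoxicity, read by MTT assay; on this read-out lower numbers stand for higher toxicity in this test and higher numbers for lower toxicity in this test. Compound 1 (`O=C(CSc1nncnc1-c1cccc2ccccc12)Nc1ccc(Cl)cc1Cl`) gives 254000 nM, and compound 2 (`O=C(CSc1nncnc1-c1cccc2ccccc12)Nc1ccccc1Br`) gives 87000 nM, the lower of the two numbers. The next compound, compound 3 (`O=C(CSc1nncnc1-c1cccc2ccccc12)Nc1ccccc1F`), differs from compound 2 in a single place: fluoro in place of bromo on an aromatic carbon. Put simply, this is fluoro in place of bromo on an aromatic carbon, ortho to a large group.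

Among the compounds with values here, only one measured step bears on this swap: a 2.9-fold lower number from compound 1 to compound 2 (0.47 log units; beyond the scatter). That step was modest and is a different change, 2-bromophenyl in place of 2,4-dichlorophenyl, so it offers a guide to size but not to direction. With so little data, a step no larger than that one is expected, and a slight rise from the lower of the two numbers seems a little more likely than a fall. The estimate is a 1.4-fold higher number from compound 2 to compound 3 (0.14 log units; within the scatter), an expected shift that may not stand clear of the usual scatter. Compound 3 is estimated at 120000 nM, with an expected range from 50000 nM to 290000 nM.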

Compound 3, half-maximal cytotoxic concentration: 65000 nM
Estimate against measurement, compound 3: 1.8-fold (0.27 log units) above; low and high end bracket the measured number.
By their numbers in this assay, from the lowest: compounds 3 and 2 (each within the scatter of the next); then compound 1.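

In this assay, fluoro in place of bromo on this aromatic carbon, ortho to a large group, gives a 1.3-fold lower number from compound 2 to compound 3 (0.13 log units; within the scatter) and so leaves compound 2 and compound 3 within the usual scatter of each other. The other new step, 2-fluorophenyl in place of 2,4-dichlorophenyl on the amide-type nitrogen, is a 3.9-fold lower number from compound 1 to compound 3 (0.59 log units; beyond the scatter) and is beyond the scatter, much like a 2.9-fold lower number from compound 1 to compound 2 (0.47 log units; beyond the scatter) in the earlier comparison, so the swap of one halogen for the other does not change the standing of these two compounds relative to compound 1. Nothing at hand explains these numbers.

Bromo and fluoro are both halogens, and how a methoxy group, an amine or a carboxylic acid on this same aromatic carbon would read in this assay stays open. Also open is which of the two chloro groups of the 2,4-dichlorophenyl in compound 1 accounts for its distance from compound 2 and compound 3, a question that a plain phenyl on the amide-type nitrogen would help to frame.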